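The compounds below may be only part of what the source reports. "The series", "measured", "known", "first", "only" and "open" are said of these compounds alone.

In a functional assay on B16-F10 cells (Mus musculus) for antiproliferative activity, read by colorimetric assay and MTT assay, with a stated time of 48 h (on this read-out lower numbers stand for stronger inhibition and higher numbers for weaker inhibition), compound 1 `Cc1ccc(S(=O)(=O)NC(=O)c2cncc(C(=O)NS(=O)(=O)c3ccc(C)cc3)c2)cc1` gives 9200 nM, compound 2 `O=C(NS(=O)(=O)c1ccc(F)cc1)c1ccncc1` gives 13800 nM and compound 3 `O=C(NS(=O)(=O)c1ccc(Cl)cc1)c1ccncc1` gives 12400 nM. Compound 3 stands second highest of these three numbers, yet within the scatter of both other compounds. Compound 4 `Cc1ccc(S(=O)(=O)NC(=O)c2ccncc2)cc1` differs from it in one place: methyl in place of chloro on an aromatic carbon. This puts methyl in place of chloro on an aromatic carbon, para to a large group. Within the data shown here, the one measured step at this place, a 1.1-fold lower number from compound 2 to compound 3 (0.05 log units; within the scatter), put chloro in place of fluoro and stayed within the scatter. Going by that single step, no change beyond the scatter is expected in this assay. The estimate amounts to an expected step of a 1.0-fold lower number from compound 3 to compound 4 (0.01 log units; within the scatter). The expected value for compound 4 is 12000 nM, with a range from 7000 nM to 20000 nM.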

Compound 4, half-maximal inhibitory concentration: 16200 nM
For compound 4 the middle estimate is 1.4-fold (0.13 log units) below the measured one; the measured number falls inside the stated range.
By their numbers in this assay, from the lowest: compounds 1, 3, 2 and 4 (each within the scatter of the next).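

Methyl in place of chloro gives a 1.3-fold higher number from compound 3 to compound 4 (0.12 log units; within the scatter) and methyl in place of fluoro gives a 1.2-fold higher number from compound 2 to compound 4 (0.07 log units; within the scatter) in this assay on this read-out. So, at this place on the aromatic ring, a small carbon group reads the same as either halogen, which the fluoro and chloro pair alone could not show. Nothing available here accounts for this sameness. As far as these compounds go, all three groups are single heavy atoms, so it remains open whether something larger or different in kind, such as an amine, a carboxylic acid or a longer chain, would move the number beyond the scatter.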